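A few compounds are considered here, and "the series" means these few. Any claim that something is new, unique, unknown or untested is made for them only; others in the source may bear on it.

Compound 1 `COc1ccc(C2=NN(C3=NC(=O)/C(=C4\C(=O)Nc5ccc(Br)cc54)S3)C(c3ccc(OC)cc3)C2)cc1`: 200 nM
Compound 2 `COc1ccc(C2=NN(C3=NC(=O)/C(=C4\C(=O)Nc5ccc(Cl)cc54)S3)C(c3ccc(OC)cc3)C2)cc1`: 200 nM
Compound 3 `COc1ccc(-c2cc(-c3ccc(Cl)cc3)n(C3C(=O)Nc4ccc(Br)cc43)n2)cc1`: 7530 nM

These values come from a functional assay on cells (Cancer cell lines, Homo sapiens) for cytotoxicity, read by sulforhodamine B assay, with a stated time of 48 h; on this read-out lower numbers stand for stronger inhibition of growth and higher numbers for weaker inhibition of growth. Compound 1 and compound 2 share one core, while compound 3 is built on another; the difference between the two cores is not broken down here. From compound 1 to compound 2 the change is chloro in place of bromo on an aromatic carbon, and the step it made was no change at the digits printed from compound 1 to compound 2 (within the scatter). Compound 4 `COc1ccc(-c2cc(-c3ccc(Cl)cc3)n(C3C(=O)Nc4ccc(Cl)cc43)n2)cc1` is not yet measured. It relates to compound 3 exactly as compound 2 relates to compound 1, by the same change, (chloro in place of bromo on an aromatic carbon). Because the earlier step of no change at the digits printed from compound 1 to compound 2 (within the scatter) stayed within the scatter, the expected step this time is a 1.0-fold lower number from compound 3 to compound 4 (0.00 log units; within the scatter), equally small. On that basis compound 4 is expected to give 7500 nM in this assay, with a likely range from 3500 nM to 16000 nM.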

Compound 4, concentration for 50% growth inhibition: 4370 nM
Beside the measured number, compound 4's estimate is 1.7-fold (0.23 log units) above it; measured number inside the range.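

Chloro in place of bromo on an aromatic carbon gives a 1.7-fold lower number from compound 3 to compound 4 (0.24 log units; within the scatter), so in this assay this second core, like the first, shows no real response to the swap. The two cores agree on this change: the same change on two cores in this assay, no change at the digits printed (within the scatter) from compound 1 to compound 2 and a 1.7-fold lower number (0.24 log units; within the scatter) from compound 3 to compound 4, 1.7-fold (0.24 log units) apart, within the scatter of two such steps

This shows that, within these two pairs, the swap carries from one core to the other, but it does not show that other changes would carry over in the same way, or why this one has so little effect. The compounds shown leave open what an amine or a carboxylic acid on this aromatic carbon would do. They also leave open whether the agreement between the two cores extends to a third core.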